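The source may report more compounds than this note shows. Statements on the series, on what has been measured and on what is new or still open speak of the compounds shown alone.

Working notes on the triphosphate–diphosphate–monophosphate pair of series.

Compound 1 `O=c1[nH]c(=O)n([C@@H]2O[C@H](COP(=O)(O)OP(=O)(O)OP(=O)(O)O)[C@@H](O)[C@H]2O)cc1Br` and compound 3 `O=c1[nH]c(=O)n([C@@H]2O[C@H](COP(=O)(O)OP(=O)(O)O)[C@@H](O)[C@H]2O)cc1Br` share one core; compound 2 `Cn1c(=O)ccn([C@@H]2O[C@H](COP(=O)(O)OP(=O)(O)O)[C@@H](O)[C@H]2O)c1=O` and compound 4 `Cn1c(=O)ccn([C@@H]2O[C@H](COP(=O)(O)O)[C@@H](O)[C@H]2O)c1=O` share another, and the difference between the two cores is not broken down here. In an in vitro functional assay on 1321-N1 cells for agonist activity at P2Y purinoceptor 2 (Homo sapiens) (a higher number here means that more compound is needed for the effect, a lower number that less compound is needed), compound 1 gives 347 nM, and compound 3 gives 3670 nM, so the change a hydrogen atom in place of a group of 4 heavy atoms (3 oxygen, 1 phosphorus; no ring), on an oxygen costs an 11-fold higher number from compound 1 to compound 3 (1.02 log units; beyond the scatter). For compound 2 this assay reports only a limit, > 1000 nM. The change from compound 2 to compound 4, (a hydrogen atom in place of a group of 4 heavy atoms (3 oxygen, 1 phosphorus; no ring), on an oxygen), is the same kind of change as that from compound 1 to compound 3, made at the same place. Because the measured step of an 11-fold higher number from compound 1 to compound 3 (1.02 log units; beyond the scatter) is large, compound 4 is expected to sit further out than compound 2, and a step that the limit leaves unreadable from compound 2 to compound 4 is estimated. Compound 4 is accordingly estimated at 30000 nM in this assay, most likely reported again only as a limit.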

Compound 4, half-maximal effective concentration: > 100000 nM
Compound 4 gave a limit, no number (the forecaster's own chance of this, stated with the estimate: 85%); middle value at least 3.3-fold (0.52 log units) from the limit.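

Compound 2 gives > 1000 nM in this assay, a limit. Compound 4 gives > 100000 nM, also a limit, so the step between these two compounds cannot be read. Left open is whether the same change weighs as much on the core of compound 2 as on the core of compound 1.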